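Methyl in Place of Difluoromethyl: An Expected Step

The compounds below may be only part of what the source reports. "The series", "measured", "known", "first", "only" and "open" are said of these compounds alone.

Compound 1 `FC(F)Oc1ccccc1C1Cc2nccn2C1` was tested in a functional assay on CHO cells for agonist activity at Alpha-1A adrenergic receptor (Homo sapiens), read by FLIPR and calcium flux (on this read-out lower numbers stand for an effect already at smaller amounts and higher numbers for an effect only at larger amounts of compound), where it gives 11 nM. Among the compounds with a single number, compound 1 stands lowest. Compound 2 `COc1cccc(C2Cc3nccn3C2)c1` gives 578 nM in this assay, a gap from compound 1 that lies well beyond the scatter of repeat measurements. Compound 3 `c1ccc(C2CCc3nc[nH]c3C2)cc1` was measured repeatedly in this assay and gives 234 nM; 123 nM; 315 nM (3 entries); these repeats, (the several entries of compound 3 in this assay, 234 nM; 123 nM; 315 nM (3 entries)), show how much one compound can move between runs.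

Compound 4 `COc1ccccc1C1Cc2nccn2C1` has not yet been measured. It differs from compound 1 in one place: methyl in place of difluoromethyl on an oxygen on an aromatic ring. Within the data shown here, no pair of measured compounds shows this exact change on its own, so the size of the step has to be estimated from the structures and the numbers at hand. A moderate rise in the number is expected at the step of a 3.6-fold higher number from compound 1 to compound 4 (0.56 log units; beyond the scatter), beyond the scatter but not a large one. Compound 4 is therefore expected to give about 40 nM in this assay, most likely between 10 nM and 200 nM.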

Compound 4, half-maximal effective concentration: 22 nM
The estimate for compound 4 lay 1.8-fold (0.26 log units) above the measured number, within the range that was stated.
By their numbers in this assay, from the lowest: compounds 1 and 4 (each within the scatter of the next); then compound 2.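

Measured in this assay the change from difluoromethoxy to methoxy gives a 2.0-fold higher number from compound 1 to compound 4 (0.30 log units; within the scatter) and so leaves the two compounds indistinguishable on this read-out. Among these compounds, this is the first direct view of this change at this position, and in this single pair the two fluorine atoms are not needed to keep the number low, since methoxy does as well as difluoromethoxy. A step of this size is no larger than the movement of one compound between runs: the several entries of compound 3 in this assay, 234 nM; 123 nM; 315 nM (3 entries).

From the compounds shown here alone, what remains open is whether a hydroxyl group, an ethoxy group or a longer chain in this place would keep the number as low. Whether the same swap behaves alike at other places on the aromatic ring or on another core also stays unanswered, as one pair cannot settle that.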